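The compounds below may be only part of what the source reports. "The series", "measured", "known", "first", "only" and "open" are said of these compounds alone.

Compound 1 `COC(=O)c1c(-c2ccc(O)cc2)oc2ccccc2c1=O`: > 25 ug/mL
Compound 2 `COc1cc(-c2cc(=O)c3cc(O)ccc3o2)cc(OC)c1OC`: 9.82 ug/mL
Compound 3 `COc1cc(-c2cc(=O)c3cc(O)ccc3o2)cc(OC)c1O`: not yet measured

All three compounds belong to one small set examined in a functional assay on A549 cells (Homo sapiens) for cytotoxicity, read by MTT assay, with a stated time of 6 days; on this read-out lower numbers stand for an effect already at smaller amounts and higher numbers for an effect only at larger amounts of compound. In this assay, among the measured compounds shown here, compound 2 gives 9.82 ug/mL, the only exact number available so far. For compound 1, the reading of > 25 ug/mL is a limit and not a number. Compound 2 therefore has no exact value to be ranked against.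

Compound 3 differs from compound 2 in one place: hydrogen in place of methyl on an oxygen on an aromatic ring. Put simply, a methoxy group becomes a hydroxy group, with hydrogen in place of methyl on an oxygen on an aromatic ring.

For the measured compounds named here, no two measured compounds differ in only one place, so the data contain no direct precedent for this change. With so little to go on, the expectation is modest: no change beyond the usual scatter, with a slight lean toward higher numbers. The expected step is a 1.3-fold higher number from compound 2 to compound 3 (0.12 log units; within the scatter). For compound 3, the estimated value is 13 ug/mL, with an expected range from 5 ug/mL to 25 ug/mL.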

Compound 3, concentration for half-maximal effect: > 25 ug/mL
Compound 3 gave a limit, no number (the forecaster's own chance of this, stated with the estimate: 15%); middle value at least 1.9-fold (0.28 log units) from the limit.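

In this assay, among the compounds shown here, this pair gives the first direct reading of what the methyl on this oxygen on an aromatic ring is worth: turning the methoxy group into a hydroxy group gives an at least 2.5-fold higher number from compound 2 to compound 3 (0.40 log units; beyond the scatter). The reading of compound 3, > 25 ug/mL, is a limit of the assay and not a number. The step therefore has a floor but no known upper end, and this limit is shared within the small set: the limit of > 25 ug/mL in this assay, at which 2 of the 3 values shown sit.

The compounds shown do not tell how a longer chain such as ethyl, or an acetyl group, would read on this same oxygen, or whether the same change at the other methoxy groups of compound 2 would have a similar result. They also leave open whether an amine in place of the hydroxy group of compound 3 would bring the number back toward that of compound 2.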